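The source may report more compounds than this note shows. Statements on the series, on what has been measured and on what is new or still open speak of the compounds shown alone.

Working notes on the series. Going by the values given here, compound 1 `CCC(CC)Nc1nc(C)c(-c2ccc(Cl)cc2Cl)nc1C` and compound 2 `CCc1nc(NC(CC)CC)c(OC)nc1-c1ccc(OC)cc1C(F)(F)F` are the two compounds measured so far. In an assay on IMR-32 cells for displacement of a labelled ligand from corticotropin-releasing factor receptor 1 (Homo sapiens), read by scintillation counting, with a stated time of 2 h (on this read-out higher numbers stand for weaker inhibition and lower numbers for stronger inhibition), compound 1 gives 27 nM, and compound 2 gives 2.2 nM. Of the two numbers compound 2 holds the lower one; the nearest is compound 1, whose number stands higher by a margin beyond the scatter, so compound 2 is the stronger binder of the pair. Compound 3 `CCc1nc(-c2ccc(OC)cc2C(F)(F)F)c(CC)nc1NC(CC)CC` has not yet been measured. It differs from compound 2 in one place: ethyl in place of methoxy on an aromatic carbon. Among the compounds with values here, no measured pair in the set shares this exact change, so the size of the step rests on judgement. Such an exchange is expected to move the number in this assay only modestly, with no lean in either direction that goes beyond the scatter. The expected step from compound 2 to compound 3 is a 1.4-fold higher number from compound 2 to compound 3 (0.13 log units; within the scatter). Compound 3 is accordingly estimated to give 3 nM in this assay, within a range from 1 nM to 10 nM.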

Compound 3, inhibition constant: 4.4 nM
Beside the measured number, compound 3's estimate is 1.5-fold (0.17 log units) below it, within the range that was stated.
By their numbers in this assay, from the lowest: compounds 2 and 3 (each within the scatter of the next); then compound 1.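

In this assay, the exchange on the aromatic carbon ortho to a (pentan-3-yl)amino group and next to the ring nitrogen gives a 2.0-fold higher number from compound 2 to compound 3 (0.30 log units; within the scatter), a step that stays within the scatter. Going by these compounds alone, this is the first one-place comparison, and it shows that at this position the methoxy, with its oxygen and hydrogen-bond acceptor, can give way to the all-carbon ethyl without a step beyond the scatter. No available measurement bears on why these two groups give values within the scatter of each other.

The compounds shown leave open whether this position accepts only groups of this size or also a longer chain such as butyl. They also leave open how an amine or a hydroxyl on the same carbon would read.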